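Amino in Place of Methyl: From Compound 3 to Compound 4

A few compounds are considered here, and "the series" means these few. Any claim that something is new, unique, unknown or untested is made for them only; others in the source may bear on it.

Of the compounds shown here, three have been tested in a functional assay on MT2 cells (Homo sapiens) for cytotoxicity, read by MTT assay; on this read-out lower numbers stand for higher toxicity in this test and higher numbers for lower toxicity in this test. Compound 1 `CC(C)=CCOc1cc(Nc2nccs2)ccc1C(=O)O` gives 17000 nM and compound 2 `Clc1ccc(Nc2nccs2)cc1OCc1ccoc1` gives 26000 nM. For compound 3 `CC(C)=CCOc1cc(Nc2nccc(C)n2)ccc1Cl` this assay reports only a limit, < 200 nM, not a number. That limit is the limit of < 200 nM in this assay, at which 1 of the 3 values shown sits. Compound 4 `CC(C)=CCOc1cc(Nc2nccc(N)n2)ccc1Cl` differs from compound 3 in one place (amino in place of methyl on an aromatic carbon). Among the compounds with values here, no two measured compounds differ in a single place, so nothing measured here shows how large such a step is. The change is expected to lessen the toxicity seen for compound 3, an estimated step of an at least 7.5-fold higher number from compound 3 to compound 4 (0.87 log units; beyond the scatter) in this assay, though this rests on little. Compound 4 is estimated at 1500 nM, within 200 nM to 15000 nM.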

Compound 4, half-maximal cytotoxic concentration: 500 nM
For compound 4 the middle estimate is 3.0-fold (0.48 log units) above the measured one, and the stated range covers the measured number.
By their numbers in this assay, from the lowest: compound 4; then compounds 1 and 2 (each within the scatter of the next). At a limit, below all of these: compound 3.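

Amino in place of methyl on this aromatic carbon gives the first step measured at this position in this assay: an at least 2.5-fold higher number from compound 3 to compound 4 (0.39 log units; beyond the scatter). The change therefore lessens toxicity in this test, and compound 4 has a real number where compound 3 has only a limit. The true step may be larger, since it is measured from that reading: the limit of < 200 nM in this assay, at which 1 of the 4 values shown sits.

On these data alone, whether a methylamino group, a dimethylamino group or a hydroxyl group at this carbon would shift the number further remains open. So does whether amino has the same effect on other cores.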